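The compounds below may be only part of what the source reports. "The series", "measured", "known", "first", "only" and "open" are said of these compounds alone.

compound 1 `Cc1nc2cnccc2n1CC1CCN(C(=O)N[C@@H](C)c2ccccc2)CC1`: 0.21 mg/kg
compound 2 `CCOC(=O)[C@@H](NC(=O)N1CCC(Cn2c(C)nc3cnccc32)CC1)c1ccccc1`: 0.061 mg/kg

For the measured compounds named here, in a functional assay on the whole organism (arterial blood) with Rattus norvegicus as the target (a lower number here means that less compound is needed, a higher number that more compound is needed for the effect), compound 2 gives 0.061 mg/kg, the lower of the two numbers so far. Compound 1 gives 0.21 mg/kg, a higher dose by more than the usual scatter of repeated measurements.

The next compound to be tested is compound 3 `CCOC(=O)[C@H](NC(=O)N1CCC(Cn2c(C)nc3cnccc32)CC1)c1ccccc1`. It differs from compound 2 only in configuration as drawn (the two compounds have the same atoms and bonds and differ only in configuration as drawn: 1 of 1 stereo elements differ; a stereocentre at a saturated chain carbon is drawn S in compound 2 and R in compound 3). The atoms and bonds are the same, but the stereocentre at a saturated chain carbon is drawn S in compound 2 and R in compound 3.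

Going by the values given here, no measured pair here differs in configuration alone, so the data do not show how large such a step can be. Compound 2 already has the lower number at 0.061 mg/kg, so a move toward a higher dose, beyond the scatter, seems more likely than a further fall, though no change at all cannot be ruled out. The expected move is a 4.1-fold higher number from compound 2 to compound 3 (0.61 log units; beyond the scatter). For compound 3, the estimated value in this assay is 0.25 mg/kg, with an expected range from 0.05 mg/kg to 1.5 mg/kg.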

Compound 3, dose for 50% inhibition: 0.069 mg/kg
Beside the measured number, compound 3's estimate is 3.6-fold (0.56 log units) above it, within the range that was stated.
By their numbers in this assay, from the lowest: compounds 2 and 3 (each within the scatter of the next); then compound 1.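

At this saturated chain carbon, drawing the stereocentre R rather than S leaves the dose in this assay within the scatter (a 1.1-fold higher number from compound 2 to compound 3 (0.05 log units; within the scatter)), so in this ester series the spatial arrangement at this carbon makes no difference that the assay can detect, and the comparison is a clean one: the fact that compounds 2 and 3 differ only in the configuration as drawn. What does register at the same carbon is the group it carries: with ethoxycarbonyl in place of methyl, the step is a 3.0-fold lower number from compound 1 to compound 3 (0.48 log units; beyond the scatter), which lies beyond the scatter but is modest in size. The earlier compounds could show neither point on its own, and together these steps suggest that, among the compounds shown, the identity of the group at this carbon counts for more than its configuration.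

Whether configuration counts equally little with methyl on this carbon stays open, as does the reason for the step from methyl, since a whole-animal dose does not separate the possible causes. Going by these compounds, it is also open how a carboxylic acid, a primary amide or a longer ester chain such as butoxycarbonyl would behave at this carbon in place of ethoxycarbonyl.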